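This account rests on a few compounds, and the source may have more. Where it says the series, first, only, none or still open, it means among the compounds named here.

Compound 1 `N#CC1=C(N)OC(c2c[nH]c3ccccc23)=C(C#N)C1c1cccc2ccccc12`, in a functional assay, tested at 100 ug/mL (a lower number here means a weaker effect, a higher number a stronger effect of the compound at the concentration tested), compound 1 gives 6.8%.
Compound 2 `N#CC1=C(N)OC(c2c[nH]c3ccccc23)=C(C#N)C1c1ccccc1F`, in this assay compound 2 gives "not active" (no number reported).
Compound 3 `Cc1ccc(C2C(C#N)=C(N)OC(c3c[nH]c4ccccc34)=C2C#N)cc1`, in this assay compound 3 gives 5.5%.

Compound 3 holds the lower of the two numbers that exist, yet its gap to compound 1, a number 1.3 percentage points lower from compound 1 to compound 3 (within the scatter), lies within the scatter, and compound 2 returned no number at all. Compound 4 `COc1ccc(C2C(C#N)=C(N)OC(c3c[nH]c4ccccc34)=C2C#N)cc1` differs from compound 3 only in the group on the saturated ring carbon: methoxy in place of methyl on an aromatic carbon. Within the data shown here, no measured pair shows methoxy against methyl; the one step that touches the same position, from compound 1 to compound 3, was within the scatter. Compound 4 is therefore expected to sit close to compound 3, with a step of a number 0.5 percentage points higher from compound 3 to compound 4 (within the scatter) that does not exceed the scatter, so compound 4 is estimated at 6%, between 0% and 14%.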

Compound 4, a percentage reported as activity, at one concentration (the size of the read-out at that concentration, not a potency): 20%
Beside the measured number, compound 4's estimate is 14 percentage points below it; the whole stated range lies below it.
By their numbers in this assay, from the lowest: compounds 3 and 1 (each within the scatter of the next); then compound 4.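

In this assay, the group on the saturated ring carbon can move the read-out beyond the scatter: methoxy in place of methyl, para to a large group, gives a clear rise (a number 14.5 percentage points higher from compound 3 to compound 4 (beyond the scatter)). The 4-methoxyphenyl group also stands apart from naphthalen-1-yl (a number 13.2 percentage points higher from compound 1 to compound 4 (beyond the scatter)), which the 4-methylphenyl group did not. No measurement shown bears on the reason for this rise. As far as these compounds go, whether ethoxy, hydroxy or an amine in the same place would match or exceed methoxy remains open.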